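This account rests on a few compounds, and the source may have more. Where it says the series, first, only, none or still open, it means among the compounds named here.

Measured so far in a functional assay on DU-145 cells (Homo sapiens) for cytotoxicity, read by ELISA, with a stated time of 4 days; on this read-out lower numbers stand for stronger inhibition and higher numbers for weaker inhibition:
- compound 1, `Cc1ccsc1-c1cc(-c2ccoc2)cc(-c2ccc(Cl)cc2)n1`: 20100 nM
- compound 2, `Cc1ccc(-c2cc(-c3ccoc3)cc(-c3ccc(Cl)s3)n2)cc1`: 25300 nM

Both compounds share one core and both sit at weak inhibition on this read-out. Among the measured compounds shown here, compound 2 stands at the higher of the two numbers, with compound 1 as its only neighbour; the gap between them lies within the scatter, so no order between the two can be read from the values shown.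

Compound 3, `Clc1ccc(-c2cc(-c3ccoc3)cc(-c3ccc(Cl)s3)n2)cc1`, is the next member and has not yet been measured in this assay. It differs from compound 2 in one place: chloro in place of methyl on an aromatic carbon. For the measured compounds named here, no pair of measured compounds shows this exchange, so the size of the step cannot be taken from the data; a small step is expected for compound 3, in no set direction and not beyond the scatter. The step from compound 2 is expected to be about a 1.2-fold lower number from compound 2 to compound 3 (0.06 log units; within the scatter).

Estimate for compound 3 in this assay: 22000 nM, with a range of 9000 nM to 55000 nM.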

Compound 3, half-maximal inhibitory concentration: 29500 nM
Estimate against measurement, compound 3: 1.3-fold (0.13 log units) below; low and high end bracket the measured number.
By their numbers in this assay, from the lowest: compounds 1, 2 and 3 (each within the scatter of the next).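

In this assay, 4-methylphenyl to 4-chlorophenyl, with chloro in place of methyl on an aromatic carbon para to a large group, gives a 1.2-fold higher number from compound 2 to compound 3 (0.07 log units; within the scatter) and so does not separate the two groups at this position on this read-out. The exchange of 3-methylthiophen-2-yl for 5-chlorothiophen-2-yl gives a 1.5-fold higher number from compound 1 to compound 3 (0.17 log units; within the scatter) and likewise yields no order, leaving all three compounds together at weak inhibition. No separate data bear on this result.

Among the compounds shown here, what an amine, a carboxylic acid or a longer chain would do in place of the chloro of compound 3 stays open, as this position is seen only with methyl and chloro. For the compounds shown here, every step so far lies within the scatter, so it also remains open whether any change on the shared core can move the number clear of it.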